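The compounds below may be only part of what the source reports. "The series", "measured", "known", "first", "only" and "open" are said of these compounds alone.

Working notes on the series. In a functional assay on A549 cells (Homo sapiens) for cytotoxicity (on this read-out higher numbers stand for an effect only at larger amounts of compound and lower numbers for an effect already at smaller amounts), compound 1 `COC1=C(C)C(=O)/C(=C(O)/C=C/c2cccc(OC)c2)C(=O)C1(C)C` gives 2.8 ug/mL and compound 2 `COC1=C(C)C(=O)/C(=C(O)/C=C/c2ccccc2C)C(=O)C1(C)C` gives 4.6 ug/mL. For the measured compounds named here, these two values lie within the scatter of each other, so compound 2 cannot be separated from compound 1 on the numbers so far. Compound 3 `C=Cc1ccccc1/C=C/C(O)=C1/C(=O)C(C)=C(OC)C(C)(C)C1=O` differs from compound 2 in one place: vinyl in place of methyl on an aromatic carbon, ortho to a large group. Going by the values given here, the one measured step that bears on this change is a 1.6-fold higher number from compound 1 to compound 2 (0.22 log units; within the scatter), with 2-methylphenyl in place of 3-methoxyphenyl. Among the compounds with values here, no measured compound carries a vinyl group, so this evidence is indirect. No step beyond the scatter is expected in this assay, and the expected step is a 1.2-fold lower number from compound 2 to compound 3 (0.06 log units; within the scatter). For compound 3 the estimated value is 4 ug/mL, with an expected range of 1.8 ug/mL to 9 ug/mL.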

Compound 3, concentration for half-maximal effect: 2.2 ug/mL
Beside the measured number, compound 3's estimate is 1.8-fold (0.26 log units) above it, and the stated range covers the measured number.
By their numbers in this assay, from the lowest: compounds 3, 1 and 2 (each within the scatter of the next, the first and the last beyond it).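

For the compounds shown here, at the aromatic carbon ortho to a large group, vinyl in place of methyl gives the first step that clears the scatter in this assay (a 2.1-fold lower number from compound 2 to compound 3 (0.32 log units; beyond the scatter)), although the margin is modest. The position therefore registers a change as small as methyl to vinyl, whereas 2-vinylphenyl in place of 3-methoxyphenyl stays within the scatter (a 1.3-fold lower number from compound 1 to compound 3 (0.10 log units; within the scatter)), so the two groups cannot be separated. No measurement at hand accounts for the methyl to vinyl step. Open, from the compounds shown here alone, is whether an ethyl group, a longer chain or an aminomethyl group at this carbon would continue the step or reverse it. Also open, going by these compounds, is whether vinyl gives a similar step on other carbons of the same aromatic ring.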